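Bromo for chloro on a benzyl thioether: expectation for compound 4

The compounds below may be only part of what the source reports. "The series", "measured", "known", "first", "only" and "open" are said of these compounds alone.

Three compounds that share a core were tested in a functional assay on HeLa cells (Homo sapiens) for antiproliferative activity, read by MTT assay, with a stated time of 48 h; a lower number here means a stronger inhibitor, a higher number a weaker inhibitor. Compound 1 `Clc1ccccc1CSc1nnc(-c2cnccn2)n1-c1ccccc1` gives only a limit of the assay, > 50000 nM. Compound 2 `Brc1ccccc1CSc1nnc(-c2cnccn2)n1-c1ccccc1` likewise gives a limit, > 50000 nM. Compound 3 `Clc1ccc(CSc2nnc(-c3cnccn3)n2-c2ccccc2)cc1` also gives a limit, > 50000 nM.

Compound 1 and compound 2 differ by bromo in place of chloro on an aromatic carbon, and the step that the two limits leave unreadable from compound 1 to compound 2 cannot be sized because of the limit of > 50000 nM in this assay, at which 3 of the 3 values shown sit. Compound 1 and compound 3 differ in their cores by 4-chlorophenyl in place of 2-chlorophenyl on a saturated chain carbon bound to a sulfur, and the steps a step that the two limits leave unreadable from compound 1 to compound 3 and a step that the two limits leave unreadable from compound 2 to compound 3 are likewise not readable.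

Compound 4 `Brc1ccc(CSc2nnc(-c3cnccn3)n2-c2ccccc2)cc1` has not been measured. It differs from compound 3 by bromo in place of chloro on an aromatic carbon. This is the same kind of change as that from compound 1 to compound 2, though around the place the two differ: there the bromo sits ortho to a large group, here para to a large group. Because (the limit of > 50000 nM in this assay, at which 3 of the 3 values shown sit), the expected step that the limit leaves unreadable from compound 3 to compound 4 from compound 3 is estimated to be small. Compound 4 is therefore expected to give about 80000 nM, most likely again as a limit, with an estimated range from 30000 nM to 300000 nM.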

Compound 4, half-maximal inhibitory concentration: 8630 nM
The estimate for compound 4 lay 9.3-fold (0.97 log units) above the measured number; the measured number lies below the stated range.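

Bromo in place of chloro, para to a large group, gives an at least 5.7-fold lower number from compound 3 to compound 4 (0.76 log units; beyond the scatter) in this assay, so on this core the change has a readable effect. Compound 4 also stands apart from the other two compounds, with an at least 5.7-fold lower number from compound 2 to compound 4 (0.76 log units; beyond the scatter) when 4-bromophenyl replaces 2-bromophenyl, and an at least 5.7-fold lower number from compound 1 to compound 4 (0.76 log units; beyond the scatter) when it replaces 2-chlorophenyl. This does not show that the change carries over from one core to the other, since the same swap from compound 1 to compound 2 cannot be read, nor can the other steps among the first three compounds: the limit of > 50000 nM in this assay, at which 3 of the 4 values shown sit.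

The compounds shown leave open whether the number would fall further with an amine or a carboxylic acid in place of the bromo. They also leave open whether bromo in place of chloro would give a readable step with a longer chain between the sulfur and the ring.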